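This account rests on a few compounds, and the source may have more. Where it says the series, first, only, none or still open, it means among the compounds named here.

Measured so far:
Compound 1, `O=C(NCc1ccccc1)c1csc(-c2c[nH]c3ccccc23)n1` — in a functional assay on LNCaP cells (Homo sapiens) for cytotoxicity, read by MTT assay, with a stated time of 48 h, in the absence of a further agent (a higher number here means a weaker inhibitor, a lower number a stronger inhibitor), compound 1 gives > 100000 nM, which is a limit of the assay and not a number.
Compound 2, `O=C(Nc1ccccc1)c1csc(-c2c[nH]c3ccccc23)n1` — in this assay compound 2 gives > 100000 nM, again a limit of the assay.

Going by the values given here, compound 2 thus stands at the edge of what the assay can report, and its one measured neighbour does the same. The change from compound 1 to compound 2, phenyl in place of benzyl on an amide-type nitrogen, is a step that the two limits leave unreadable from compound 1 to compound 2. Both shown values sit at the limit of > 100000 nM in this assay, at which 2 of the 2 values shown sit, so no step can be read from them and nothing shows how strong or weak compound 2 truly is.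

Compound 3, `Cc1ccc(NC(=O)c2csc(-c3c[nH]c4ccccc34)n2)cc1`, differs from compound 2 by methyl in place of hydrogen on an aromatic carbon. Among the compounds with values here, no measured step bears on a change of this kind, and the one step that exists is unreadable. With both known values at the limit, the expectation for compound 3 in this assay is that the step that the limit leaves unreadable from compound 2 to compound 3 leaves the value at the limit once more. The estimate for compound 3 is therefore 150000 nM, with a range from 30000 nM to 600000 nM, and most likely only a limit would be reported.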

Compound 3, half-maximal inhibitory concentration: > 100000 nM
Compound 3 ended at the assay's limit; the forecaster's own chance of this, stated with the estimate: 80%; the middle value lies beyond the limit too.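

No step can be read among compound 1, compound 2 and compound 3, since each value is a limit and not a number: the limit of > 100000 nM in this assay, at which 3 of the 3 values shown sit.

The compounds shown leave open how strong or weak each truly is in this assay and whether any change to them would bring a value within reach.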